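This account rests on a few compounds, and the source may have more. Where it says the series, first, only, none or still open, it means among the compounds named here.

Compound 3 `Cc1cc(C)c(CN2CCc3c(Cl)cc([C@H](CO)[C@@H]4CCCO4)c(Cl)c3C2=O)c(=O)[nH]1` gives 10 nM in an assay for inhibition of histone-lysine N-methyltransferase EZH2 variant Y641N (Homo sapiens), read by scintillation counting, with a stated time of 60 min, in the presence of a further agent that is not named here (a higher number here means a weaker inhibitor, a lower number a stronger inhibitor), the highest of the two single numbers in the series; compound 1 `Cc1cc(C)c(CN2CCc3c(Cl)cc([C@H](CO)[C@H]4CCOC4)c(Cl)c3C2=O)c(=O)[nH]1` gives 0.24 nM. Compound 2 `COC(c1cc(Cl)c2c(c1Cl)C(=O)N(Cc1c(C)cc(C)[nH]c1=O)CC2)C1CCS(=O)(=O)CC1` gives 93 nM; 0.35 nM (2 entries), and the several entries of compound 2 in this assay, 93 nM; 0.35 nM (2 entries) shows how far repeats of this assay can spread. Going by the values given here, the one measured change at the same position, a 42-fold higher number from compound 1 to compound 3 (1.62 log units; beyond the scatter), is large. Compound 4 `Cc1cc(C)c(CN2CCc3c(Cl)cc([C@@H](C)CO)c(Cl)c3C2=O)c(=O)[nH]1` carries methyl in place of oxolan-2-yl on a saturated chain carbon bound to an aromatic carbon and a saturated chain carbon. Among the compounds with values here, no measured step removes the ring altogether, so the direction rests on the size of the only comparable change, which suggests that compound 4 may move well beyond the scatter, most plausibly toward a lower number than compound 3. Compound 4 is expected near 3 nM, with a range from 0.3 nM to 30 nM. The expected step is a 3.3-fold lower number from compound 3 to compound 4 (0.52 log units; beyond the scatter).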

Compound 4, inhibition constant: 260 nM
Beside the measured number, compound 4's estimate is 87-fold (1.94 log units) below it; the measured number lies above the stated range.
By their numbers in this assay, from the lowest: compound 1; then compound 3; then compound 4.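

Methyl in place of either ring gives a much weaker inhibitor in this assay: a 26-fold higher number from compound 3 to compound 4 (1.41 log units; beyond the scatter), and a 1100-fold higher number from compound 1 to compound 4 (3.03 log units; beyond the scatter). Both oxolan-3-yl and oxolan-2-yl therefore beat methyl at this saturated chain carbon, so the presence of a ring matters here and not only how it is attached. These large steps still need reading against how far repeats can spread: the several entries of compound 2 in this assay, 93 nM; 0.35 nM (2 entries)

Still open, going by these compounds, is whether the ring oxygen is needed. Cyclopentyl, which has no oxygen, or a longer chain such as propyl could separate the contribution of the oxygen from that of the carbon bulk.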